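This account rests on a few compounds, and the source may have more. Where it says the series, first, only, none or still open, it means among the compounds named here.

Measured so far in an ADME assay (liver) for metabolic stability, with Liver microsome (Rattus norvegicus) as the target, using microsomes and NADPH, with a stated time of 30 min, tested at 1 uM; on this read-out lower numbers stand for slow clearance and higher numbers for fast clearance:
- compound 1 `COc1cc(C(O)(C(F)(F)F)C(F)(F)F)cnc1N1CCN(S(=O)(=O)c2ccc(N)nc2)CC1`: < 14 mL.min-1.g-1; this value is a limit of the assay, not a number
- compound 2 `COCC#Cc1cc(C(O)(C(F)(F)F)C(F)(F)F)cnc1N1CCN(S(=O)(=O)c2ccc(N)nc2)CC1`: 399 mL.min-1.g-1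
- compound 3 `CS(=O)(=O)c1ccc(-c2cc(C(O)(C(F)(F)F)C(F)(F)F)cnc2N2CCN(S(=O)(=O)c3ccc(N)nc3)CC2)cc1`: 103 mL.min-1.g-1

Compound 3 holds the lowest of the two numbers shown in this assay. The nearest measured neighbour is compound 2, with a 3.9-fold lower number from compound 2 to compound 3 (0.59 log units; beyond the scatter). Compound 1 sits at the limit of < 14 mL.min-1.g-1 in this assay, at which 1 of the 3 values shown sits, so its distance from compound 3 is known only as an at least 7.3-fold higher number from compound 1 to compound 3 (0.86 log units; beyond the scatter).

Compound 4 `Nc1ccc(S(=O)(=O)N2CCN(c3ncc(C(O)(C(F)(F)F)C(F)(F)F)cc3-c3ccc4ocnc4c3)CC2)cn1` is not yet measured. Its change from compound 3 is 1,3-benzoxazol-5-yl in place of 4-(methylsulfonyl)phenyl on an aromatic carbon.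

Both measured steps that end at compound 3, an at least 7.3-fold higher number from compound 1 to compound 3 (0.86 log units; beyond the scatter) and a 3.9-fold lower number from compound 2 to compound 3 (0.59 log units; beyond the scatter), exchange a small substituent for an aryl group at the same aromatic carbon; neither exchanges one aryl group for another, so none bears directly on the step to compound 4. The shared core and the 2,2,2-trifluoro-1-hydroxy-1-(trifluoromethyl)ethyl group are unchanged, and the group that leaves and the group that enters are of similar size. The expectation for compound 4 is therefore a value close to compound 3, with a step of a 1.5-fold higher number from compound 3 to compound 4 (0.16 log units; within the scatter) that may fall within the scatter, though a larger upward move cannot be excluded. Compound 4 is estimated at 150 mL.min-1.g-1, with a range of 55 mL.min-1.g-1 to 420 mL.min-1.g-1.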

Compound 4, intrinsic clearance in microsomes: 120 mL.min-1.g-1
The estimate for compound 4 lay 1.3-fold (0.10 log units) above the measured number; the range from low to high includes it.
By their numbers in this assay, from the lowest: compounds 3 and 4 (each within the scatter of the next); then compound 2. At a limit, below all of these: compound 1.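

Working notes on the aryl groups at this position. In this assay, the only exchange of one aryl group for another shown, made on an aromatic carbon of a six-membered aromatic ring with 1 nitrogen, gives a 1.2-fold higher number from compound 3 to compound 4 (0.07 log units; within the scatter), so 4-(methylsulfonyl)phenyl and 1,3-benzoxazol-5-yl are not told apart on this read-out, although the first carries one six-membered aromatic ring and the second adds a five-membered aromatic ring with 2 hetero atoms. Placing 1,3-benzoxazol-5-yl where 3-methoxyprop-1-yn-1-yl stood gives a 3.3-fold lower number from compound 2 to compound 4 (0.52 log units; beyond the scatter), which means that two different aryl groups, in compound 3 and compound 4, now both give lower numbers than compound 2. Compound 1 carries methoxy at this carbon and its value is a limit, not a number, so the step from it reads only as an at least 8.5-fold higher number from compound 1 to compound 4 (0.93 log units; beyond the scatter): the limit of < 14 mL.min-1.g-1 in this assay, at which 1 of the 4 values shown sits.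

As far as these compounds go, it remains open whether the level shared by compound 3 and compound 4 would hold for an unsubstituted phenyl group or for an aryl group carrying an amine or a carboxylic acid. Also open, from the compounds shown here alone, is where a plain alkyl chain or a nitrile at this carbon would fall relative to methoxy and 3-methoxyprop-1-yn-1-yl.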